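Trimethoxyphenyl Analogue of a Series Without Measurable Cytotoxicity

The source may hold more compounds than are shown below. What is called first, only, known or untested is meant among the compounds shown, and "the series" means these compounds.

Measured so far:
Compound 1 `N#Cc1c(-c2ccccc2)c(C#N)c(=O)n(/N=C/c2cn(-c3ccccc3)nc2-c2ccccc2)c1N` gives > 200 ug/mL in an ADME assay on HeLa cells (Homo sapiens) for cytotoxicity, read by MTT assay (a higher number here means a weaker inhibitor, a lower number a stronger inhibitor), a limit of the assay.
Compound 2 `N#Cc1c(-c2cccc(Cl)c2)c(C#N)c(=O)n(/N=C/c2cn(-c3ccccc3)nc2-c2ccccc2)c1N` gives > 200 ug/mL in this assay, also a limit.
Compound 3 `N#Cc1c(-c2cccc(F)c2)c(C#N)c(=O)n(/N=C/c2cn(-c3ccccc3)nc2-c2ccccc2)c1N` gives > 200 ug/mL in this assay, also a limit.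

Compound 1 stands only at a limit in this assay, and the two further values are limits too; all three sit at the limit of > 200 ug/mL in this assay, at which 3 of the 3 values shown sit. Compound 4 `COc1cc(-c2c(C#N)c(N)n(/N=C/c3cn(-c4ccccc4)nc3-c3ccccc3)c(=O)c2C#N)cc(OC)c1OC` differs from compound 1 by 3,4,5-trimethoxyphenyl in place of phenyl on an aromatic carbon. The measured steps, a step that the two limits leave unreadable from compound 1 to compound 2, a step that the two limits leave unreadable from compound 1 to compound 3 and a step that the two limits leave unreadable from compound 2 to compound 3, concern halogen exchange on the phenyl and cannot be sized; none shows a step beyond the scatter, and none touches the trimethoxyphenyl change. Compound 4 is therefore expected to remain at the limit, with a number no higher from compound 1 to compound 4 (the limit leaves the size open) estimated as no step beyond the scatter. The estimate for compound 4 is 200 ug/mL, between 100 ug/mL and 400 ug/mL.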

Compound 4, half-maximal inhibitory concentration: > 200 ug/mL
Compound 4 ended at the assay's limit (the forecaster's own chance of this, stated with the estimate: 80%); the middle value sits exactly at the limit.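

Among these compounds, compound 4 gives > 200 ug/mL in this assay, which is a limit, and with compound 1, compound 2 and compound 3 also at limits, no step to compound 4 can be read. On these data alone, the true strength of all four compounds in this assay stays open, and with it any effect of 3,4,5-trimethoxyphenyl in place of phenyl.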